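Notes on the anilino series: methylsulfanyl for chloro

This account rests on a few compounds, and the source may have more. Where it says the series, first, only, none or still open, it means among the compounds named here.

Three members of the series have been run in a functional assay (aorta) with Rattus norvegicus as the target; on this read-out lower numbers stand for stronger inhibition and higher numbers for weaker inhibition. Compound 1 `CC1(C)Oc2ccc(C#N)cc2[C@@H](/N=C(\NC#N)Nc2ccc(Cl)cc2)[C@@H]1O` gives 1800 nM, the second highest of the three numbers. Compound 2 `CC1(C)Oc2ccc(C#N)cc2[C@@H](/N=C(\NC#N)Nc2cccc(Cl)c2)[C@@H]1O` gives 600 nM, and the step of a 3.0-fold lower number from compound 1 to compound 2 (0.48 log units; beyond the scatter) comes from 3-chlorophenyl in place of 4-chlorophenyl on the amine nitrogen. Compound 3 `CC1(C)Oc2ccc(C#N)cc2[C@@H](/N=C(\NC#N)Nc2ccc(C(F)(F)F)cc2)[C@@H]1O` gives 8100 nM; the step of a 4.5-fold higher number from compound 1 to compound 3 (0.65 log units; beyond the scatter) arises from trifluoromethyl in place of chloro on an aromatic carbon, and the step of a 14-fold higher number from compound 2 to compound 3 (1.13 log units; beyond the scatter) is the largest in the set.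

Compound 4 `CSc1ccc(N/C(=N/[C@@H]2c3cc(C#N)ccc3OC(C)(C)[C@H]2O)NC#N)cc1` carries the change (methylsulfanyl in place of chloro on an aromatic carbon), on an aromatic carbon of a six-membered aromatic ring of carbon only. Going by the values given here, the only step that bears on this position is a 4.5-fold higher number from compound 1 to compound 3 (0.65 log units; beyond the scatter), where the group that entered in place of chloro weakened the result. Among the compounds with values here, no measured compound carries methylsulfanyl, so the direction is uncertain. A step of a 1.4-fold higher number from compound 1 to compound 4 (0.14 log units; within the scatter) is expected, no larger than the scatter or a modest weakening. The estimate for compound 4 in this assay is 2500 nM, with a range from 900 nM to 7000 nM.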

Compound 4, half-maximal inhibitory concentration: 6300 nM
Estimate against measurement, compound 4: 2.5-fold (0.40 log units) below, within the range that was stated.
By their numbers in this assay, from the lowest: compound 2; then compound 1; then compounds 4 and 3 (each within the scatter of the next).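

In this assay, methylsulfanyl in place of chloro weakens the result (a 3.5-fold higher number from compound 1 to compound 4 (0.54 log units; beyond the scatter)), so two different groups on this aromatic carbon, methylsulfanyl and trifluoromethyl, now each give a higher number than chloro. These two groups cannot be told apart here (a 1.3-fold lower number from compound 3 to compound 4 (0.11 log units; within the scatter)), while the gap to the 3-chlorophenyl compound is large (an 11-fold higher number from compound 2 to compound 4 (1.02 log units; beyond the scatter)). Nothing available here accounts for the step from chloro to methylsulfanyl.

On these data alone, it remains open whether methylsulfanyl would keep the lower number of compound 2 if it stood where chloro stands in the 3-chlorophenyl group. The compounds shown also do not tell how an amine, a carboxylic acid or a longer chain such as ethylsulfanyl would read on this aromatic carbon.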